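Phenyl for trifluoromethyl on the compound 1 scaffold

This account rests on a few compounds, and the source may have more. Where it says the series, first, only, none or still open, it means among the compounds named here.

In a functional assay on Raji cells (Homo sapiens) for cytotoxicity, read by CCK-8 assay, with a stated time of 24 h (a lower number here means a stronger inhibitor, a higher number a weaker inhibitor), compound 1 (`C=CC(=O)N1C(=O)CC(c2ccc(C(F)(F)F)cc2)Sc2ccccc21`) gives 47600 nM, within the scatter of compound 3 (`C=CC(=O)N1C(=O)CC(c2ccccc2C(F)(F)F)Sc2ccccc21`) at 50300 nM. Compound 2 (`C=CC(=O)N1C(=O)CC(C)Sc2ccccc21`) reads 837000 nM, beyond the scatter from compound 1, which therefore shares the low end of the three numbers with compound 3. Compound 4 (`C=CC(=O)N1C(=O)CC(c2ccc(-c3ccccc3)cc2)Sc2ccccc21`) carries phenyl in place of trifluoromethyl on an aromatic carbon, para to a large group: phenyl in place of trifluoromethyl on an aromatic carbon. Within the data shown here, no measured step covers this change, so the only guide is the close pair of compound 3 at 50300 nM and compound 1 at 47600 nM. A small move toward a lower number in this assay is expected, possibly none beyond the scatter. The expected change is a 1.4-fold lower number from compound 1 to compound 4 (0.13 log units; within the scatter). The estimate for compound 4 is 35000 nM, within an expected range of 12000 nM to 90000 nM.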

Compound 4, half-maximal inhibitory concentration: 56300 nM
Compound 4: the middle estimate sits 1.6-fold (0.21 log units) below what was measured; measured number inside the range.
By their numbers in this assay, from the lowest: compounds 1, 3 and 4 (each within the scatter of the next); then compound 2.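

In this assay, the step reads a 1.2-fold higher number from compound 1 to compound 4 (0.07 log units; within the scatter): phenyl in place of trifluoromethyl on an aromatic carbon, para to a large group, stays within the scatter. Among these compounds, this is the first single-place comparison, and at this position an added six-membered aromatic ring of carbon only goes with no readable shift in the number. No available evidence bears on the reason for this result. As far as these compounds go, whether an amine or a carboxylic acid at this position would give a number beyond the scatter remains open.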